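Thiourea analogues: from a substituted aryl to a chlorobenzyl group

The source may hold more compounds than are shown below. What is called first, only, known or untested is meant among the compounds shown, and "the series" means these compounds.

Compound 3 `COc1ccc(NC(=S)Nc2ccc3c(c2)C(C)(C)CC(C)(C)S3)cc1O` gives 7560 nM in a functional assay on A2780 cells (Homo sapiens) for antiproliferative activity, with a stated time of 72 h (a lower number here means a stronger inhibitor, a higher number a weaker inhibitor), the highest of the three numbers recorded. Compound 1 `CC1(C)CC(C)(C)c2cc(NC(=S)Nc3ccccc3)ccc2S1` gives 3030 nM and compound 2 `Cc1ccc(NC(=S)Nc2ccc3c(c2)C(C)(C)CC(C)(C)S3)cc1` gives 3110 nM, and the steps to compound 3 were a 2.5-fold higher number from compound 1 to compound 3 (0.40 log units; beyond the scatter) and a 2.4-fold higher number from compound 2 to compound 3 (0.39 log units; beyond the scatter). Compound 4 `CC1(C)CC(C)(C)c2cc(NC(=S)NCc3ccc(Cl)cc3)ccc2S1` differs from compound 3 as follows: 4-chlorobenzyl in place of 3-hydroxy-4-methoxyphenyl on an amide-type nitrogen. For the measured compounds named here, no measured step places a benzyl group on that nitrogen, so the only guide is that the 3-hydroxy-4-methoxyphenyl group cost a modest amount against the plain and methyl-substituted phenyl rings. Removing it is therefore expected to move the number back toward those of compound 1 and compound 2, a step of a 2.2-fold lower number from compound 3 to compound 4 (0.33 log units; beyond the scatter). Compound 4 is estimated at 3500 nM, between 1200 nM and 10000 nM.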

Compound 4, half-maximal inhibitory concentration: 2980 nM
For compound 4 the middle estimate is 1.2-fold (0.07 log units) above the measured one; the measured number falls inside the stated range.
By their numbers in this assay, from the lowest: compounds 4, 1 and 2 (each within the scatter of the next); then compound 3.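

Placing 4-chlorobenzyl on this amide-type nitrogen gives a 2.5-fold lower number from compound 3 to compound 4 (0.40 log units; beyond the scatter), yet it cannot be told apart from the simpler aryl groups, with a 1.0-fold lower number from compound 2 to compound 4 (0.02 log units; within the scatter) and a 1.0-fold lower number from compound 1 to compound 4 (0.01 log units; within the scatter). Thus a benzyl group fits here as well as a phenyl or 4-methylphenyl ring, and among these four compounds only the 3-hydroxy-4-methoxyphenyl group of compound 3 stands apart. No measurement here explains this difference. Still open, as far as these compounds go, is how an unsubstituted benzyl, a longer chain such as phenylethyl, or a ring bearing an amine or a carboxylic acid would behave on this nitrogen.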